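The source may report more compounds than this note shows. Statements on the series, on what has been measured and on what is new or still open speak of the compounds shown alone.

Of the compounds shown here, three that share one core have so far been tested in an assay on isolated protein for inhibition of glucose-6-phosphatase catalytic subunit 1 (Homo sapiens), tested at 100 uM; on this read-out higher numbers stand for more inhibition at the one concentration tested (going by the name of the read-out) and lower numbers for less inhibition. Compound 1 `CSc1c(C)c(-c2ccccc2)c(C#N)c(N)c1C#N` gives 0.96% in this assay. Compound 2 `CSc1c(C)c(-c2ccc(Cl)cc2)c(C#N)c(N)c1C#N` gives 19.3%, and compound 3 `COc1ccc(-c2c(C)c(SC)c(C#N)c(N)c2C#N)cc1` gives 12.3%. Compound 1 thus stands lowest of the three: a number 18.3 percentage points higher from compound 1 to compound 2 (beyond the scatter) and a number 11.3 percentage points higher from compound 1 to compound 3 (beyond the scatter), while the two higher compounds lie close to one another, a number 7 percentage points lower from compound 2 to compound 3 (within the scatter).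

Compound 4 `Cc1c(-c2ccccc2)c(C#N)c(N)c(C#N)c1N1CCC(C)CC1` has not yet been measured. It differs from compound 1 in one place: 4-methylpiperidin-1-yl in place of methylsulfanyl on an aromatic carbon. None of the three measured steps touches this part of the core; all of them alter the phenyl group, so they carry no direct information on what replacing the methylsulfanyl group does. For the measured compounds named here, the measured numbers show only that the core of compound 1 sits at the bottom of this small set and that single changes elsewhere have moved the read-out by modest amounts. The expectation for compound 4 is therefore uncertain and the range must be wide. Because compound 1 gives only 0.96%, the number estimated for compound 4 is 8%, within 0% to 35%. This would mean an expected step of a number 7 percentage points higher from compound 1 to compound 4 (within the scatter) in this assay.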

Compound 4, a percentage reported as inhibition, at one concentration (the size of the read-out at that concentration, not a potency): 10.9%
Compound 4: the middle estimate sits 2.9 percentage points below what was measured; measured number inside the range.
By their numbers in this assay, from the lowest: compounds 1, 4, 3 and 2 (each within the scatter of the next, the first and the last beyond it).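

For the compounds shown here, the position on the aromatic carbon ortho to a cyano group and ortho to a methyl group, untouched by the earlier steps, can now be read for the first time. In this assay the exchange of methylsulfanyl (2 heavy atoms, no ring) for 4-methylpiperidin-1-yl (7 heavy atoms, one six-membered non-aromatic ring) gives a number 9.9 percentage points higher from compound 1 to compound 4 (within the scatter) and so shows no clear gain or loss, although with compound 1 at 0.96% as the starting point, little room exists for a loss to appear. No measurement at hand explains this outcome.

Going by these compounds alone, the single exchange leaves open whether other groups at this position, such as a morpholine ring, a dimethylamino group or a simple methoxy group, would shift the read-out any more clearly. It also leaves open what 4-methylpiperidin-1-yl does when the phenyl group carries the chloro or methoxy substituent of compound 2 or compound 3, where the starting values are higher and a loss could be seen.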